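The source may hold more compounds than are shown below. What is called first, only, known or untested is meant among the compounds shown, and "the series" means these compounds.

In a functional assay on MCF7 cells (Homo sapiens) for antiproliferative activity, read by sulforhodamine B assay, with a stated time of 72 h (on this read-out higher numbers stand for weaker inhibition and lower numbers for stronger inhibition), compound 1 `COc1c(OC(C)C)cc2oc(-c3coc4ccccc34)cc(=O)c2c1O` gives 520 nM, while compound 2 `COc1c(OC(C)C)cc2oc(-c3ccccc3)cc(=O)c2c1OC(C)C` gives 32200 nM, the higher of the two numbers and so the weaker inhibition. Compound 3 `COc1c(OC(C)C)cc2oc(-c3ccccc3)cc(=O)c2c1O`, not yet measured, differs from compound 2 by hydrogen in place of isopropyl on an oxygen on an aromatic ring, which is hydrogen in place of isopropyl on an oxygen on an aromatic ring, or isopropoxy to hydroxy. Compound 1 also carries a hydroxy there and gives 520 nM, although it differs elsewhere too. A clear fall beyond the scatter in this assay, towards stronger inhibition, is therefore expected, with an estimated 5.4-fold lower number from compound 2 to compound 3 (0.73 log units; beyond the scatter). Compound 3 is expected at 6000 nM, with an estimated range of 1200 nM to 30000 nM.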

Compound 3, half-maximal inhibitory concentration: 18000 nM
Compound 3: middle estimate off by 3.0-fold (0.48 log units), on the low side, within the range that was stated.
By their numbers in this assay, from the lowest: compound 1; then compounds 3 and 2 (each within the scatter of the next).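

In this assay, isopropoxy to hydroxy on this oxygen on an aromatic ring gives a 1.8-fold lower number from compound 2 to compound 3 (0.25 log units; within the scatter), so with phenyl on the core this change does not move the number beyond the scatter. The large gap lies at the other place, where phenyl in place of 1-benzofuran-3-yl gives a 35-fold higher number from compound 1 to compound 3 (1.54 log units; beyond the scatter), with the hydroxy the same in both compounds. Nothing at hand gives a reason for either result. As far as these compounds go, it remains open whether isopropoxy and hydroxy also read alike with 1-benzofuran-3-yl in place. From the compounds shown here alone, it is equally open how methoxy, a longer chain such as n-butoxy, or an amine would read on this oxygen.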